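This account rests on a few compounds, and the source may have more. Where it says the series, first, only, none or still open, it means among the compounds named here.

In a functional assay on CCRF-CEM cells (Homo sapiens) (on this read-out higher numbers stand for lower toxicity in this test and lower numbers for higher toxicity in this test), three compounds sharing one core have been measured, differing only in the group on a saturated chain carbon bound to an aromatic nitrogen. Compound 1 `Cc1cn([C@@H]2O[C@H](CO[Si](C)(C)C(C)(C)C)[C@@]3(OS(=O)(=O)C=C3N)[C@H]2O[Si](C)(C)C(C)(C)C)c(=O)n(CC2CC2)c1=O` carries cyclopropyl there and gives 60400 nM as its value, while compound 2 `CCOC(=O)CCCCCn1c(=O)c(C)cn([C@@H]2O[C@H](CO[Si](C)(C)C(C)(C)C)[C@@]3(OS(=O)(=O)C=C3N)[C@H]2O[Si](C)(C)C(C)(C)C)c1=O` carries 4-(ethoxycarbonyl)butyl and gives 40600 nM as its value. These two cannot be told apart, since a 1.5-fold lower number from compound 1 to compound 2 (0.17 log units; within the scatter) is within the scatter. Compound 3 `COC(=O)/C=C/Cn1c(=O)c(C)cn([C@@H]2O[C@H](CO[Si](C)(C)C(C)(C)C)[C@@]3(OS(=O)(=O)C=C3N)[C@H]2O[Si](C)(C)C(C)(C)C)c1=O` carries 2-(methoxycarbonyl)ethenyl and gives 142000 nM as the highest number of the three, with a 2.4-fold higher number from compound 1 to compound 3 (0.37 log units; beyond the scatter) and a 3.5-fold higher number from compound 2 to compound 3 (0.54 log units; beyond the scatter) as modest steps beyond the scatter.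

Compound 4 `Cc1cn([C@@H]2O[C@H](CO[Si](C)(C)C(C)(C)C)[C@@]3(OS(=O)(=O)C=C3N)[C@H]2O[Si](C)(C)C(C)(C)C)c(=O)n(CCCN(C)C)c1=O` is still unmeasured. Its change from compound 3 is 2-(dimethylamino)ethyl in place of 2-(methoxycarbonyl)ethenyl on a saturated chain carbon bound to an aromatic nitrogen and in words 2-(dimethylamino)ethyl takes the place of 2-(methoxycarbonyl)ethenyl. Among the measured compounds shown here, no measured step makes this exact swap, so the two steps into compound 3 are the closest guide. Both compounds without 2-(methoxycarbonyl)ethenyl sit lower, compound 1 at 60400 nM and compound 2 at 40600 nM with neither going against this. Compound 4 also lacks that group, so a modest drop in this assay is expected, though three compounds are thin evidence. The expected move is a 2.4-fold lower number from compound 3 to compound 4 (0.37 log units; beyond the scatter) by this estimate. For compound 4 the estimated value is 60000 nM with an expected range from 25000 nM to 140000 nM as its upper end.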

Compound 4, half-maximal cytotoxic concentration: 10400 nM
Beside the measured number, compound 4's estimate is 5.8-fold (0.76 log units) above it; measured number below the stated range.
By their numbers in this assay, from the lowest: compound 4; then compounds 2 and 1 (each within the scatter of the next); then compound 3.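

In this assay, the group on a saturated chain carbon bound to an aromatic nitrogen can move the number much further than the first three compounds showed, and a 14-fold lower number from compound 3 to compound 4 (1.14 log units; beyond the scatter) is the largest step in the set. Compound 4 also stands clearly apart from the other two, with a 3.9-fold lower number from compound 2 to compound 4 (0.59 log units; beyond the scatter) and a 5.8-fold lower number from compound 1 to compound 4 (0.76 log units; beyond the scatter) as its remaining steps, so it has the lowest number of the four and is the most toxic in this test. Among the compounds shown here, of the groups at this place, only the 3-(dimethylamino)propyl chain contains a nitrogen, and no compound here goes against a link between that nitrogen and a lower number, although this single compound is thin support for such a link.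

As far as these compounds go, whether a primary amine or a carboxylic acid at the end of the chain, or a longer chain leading to the dimethylamino group, would give a similar drop remains open. No measurement at hand explains why the number falls with this change.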